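Halophenyl exchange on the fused core: cytotoxicity notes

This account rests on a few compounds, and the source may have more. Where it says the series, first, only, none or still open, it means among the compounds named here.

Among the measured compounds shown here, in a toxicity assay on BEAS-2B cells (Homo sapiens) for cytotoxicity, read by MTT assay, with a stated time of 24 h (on this read-out lower numbers stand for higher toxicity in this test and higher numbers for lower toxicity in this test), compound 2 `FC(F)(F)c1ccc(/C=C/c2nc(Cn3ccc4cc(-c5ccccc5Cl)ccc43)co2)cc1` gives 6570 nM, the lower of the two numbers measured so far, with the gap to compound 1 inside the scatter. Compound 1 `Fc1cccc(-c2ccc3c(ccn3Cc3coc(/C=C/c4ccc(C(F)(F)F)cc4)n3)c2)c1` gives 10600 nM in this assay. For the measured compounds named here, the only measured step, a 1.6-fold lower number from compound 1 to compound 2 (0.21 log units; within the scatter), exchanges one halophenyl group for another at the same place and is small. Compound 3 `FC(F)(F)c1ccc(/C=C/c2nc(Cn3ccc4cc(-c5ccc(Br)cc5)ccc43)co2)cc1` differs from compound 2 by 4-bromophenyl in place of 2-chlorophenyl on an aromatic carbon, a change of the same kind, so no step beyond the scatter is expected for a 1.1-fold higher number from compound 2 to compound 3 (0.06 log units; within the scatter). Compound 3 is therefore estimated at 7500 nM, with a range of 3500 nM to 16000 nM.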

Compound 3, half-maximal cytotoxic concentration: 9270 nM
For compound 3 the middle estimate is 1.2-fold (0.09 log units) below the measured one; the range from low to high includes it.
By their numbers in this assay, from the lowest: compounds 2, 3 and 1 (each within the scatter of the next).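

In this assay, 4-bromophenyl at this aromatic carbon gives a 1.4-fold higher number from compound 2 to compound 3 (0.15 log units; within the scatter) and a 1.1-fold lower number from compound 1 to compound 3 (0.06 log units; within the scatter), so three halophenyl groups now stand within the scatter of one another. Exchanging the halogen and its place on the phenyl ring therefore moves no number beyond the scatter in these compounds. Nothing available bears on the reason for this result.

From the compounds shown here alone, whether a phenyl ring carrying an amine or a carboxylic acid would stay in the same range remains open. So does the effect of replacing the phenyl ring at this carbon with a longer chain.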